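Urea and dichlorophenyl in place of the pyridine amide

The source may report more compounds than this note shows. Statements on the series, on what has been measured and on what is new or still open speak of the compounds shown alone.

compound 1 `Cc1cc(NNC(=O)Nc2cc(Cl)nc(Cl)c2)nc(-c2cnn(C)c2)c1`: > 23000 nM
compound 2 `CCOc1nc(Cl)cc2nc(NCc3cc(C)c(-c4cn(C)nc4C)cn3)[nH]c12`: 4200 nM
compound 3 `Cc1cc(CNC(=O)c2cc(Cl)nc(Cl)c2)ncc1-c1cn(C)nc1C`: < 1700 nM

In a functional assay on CHO cells for agonist activity at sphingosine 1-phosphate receptor 2 (Homo sapiens), read by fluorescence and calcium flux, with a stated time of 3 min (a higher number here means a weaker inhibitor, a lower number a stronger inhibitor), compound 3 gives only a limit, < 1700 nM, namely (the limit of < 1700 nM in this assay, at which 1 of the 3 values shown sits). Compound 1 also sits at a limit, (the limit of > 23000 nM in this assay, at which 1 of the 3 values shown sits). Compound 2 gives a number, 4200 nM. Compound 3 therefore stands as a limit only, and its place relative to compound 2 cannot be fixed from these values.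

Compound 4 `Cc1cc(CNC(=O)Nc2cc(Cl)cc(Cl)c2)ncc1-c1cn(C)nc1C` differs from compound 3 by (3,5-dichlorophenyl)amino in place of 2,6-dichloropyridin-4-yl on a carbonyl carbon. Among the compounds with values here, no measured pair isolates this change. A modest loss is expected, with the step from compound 3 to compound 4 estimated at an at least 1.7-fold higher number from compound 3 to compound 4 (0.24 log units; that floor lies within the scatter), at the edge of the scatter. Compound 4 is estimated at 3000 nM, range 600 nM to 15000 nM.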

Compound 4, half-maximal inhibitory concentration: 3200 nM
The estimate for compound 4 lay 1.1-fold (0.03 log units) below the measured number, within the range that was stated.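

In this assay, (3,5-dichlorophenyl)amino in place of 2,6-dichloropyridin-4-yl on a carbonyl carbon gives an at least 1.8-fold higher number from compound 3 to compound 4 (0.27 log units; that floor lies within the scatter). This step is only a floor, because compound 3 stands at a limit: the limit of < 1700 nM in this assay, at which 1 of the 4 values shown sits. Compound 4 gives a number, 3200 nM, so this position now carries a firm value rather than a limit alone.

As far as these compounds go, whether the ring or the amino link carries the step remains open, as does its true size. From the compounds shown here alone, the effect of a carboxylic acid or a morpholine in place of one chlorine is also open.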